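The source may hold more compounds than are shown below. What is called first, only, known or untested is meant among the compounds shown, and "the series" means these compounds.

Values measured so far in a functional assay on HeLa cells (Homo sapiens) for antiproliferative activity, read by MTT assay, with a stated time of 48 h; on this read-out lower numbers stand for stronger inhibition and higher numbers for weaker inhibition
Compound 1 `Cc1ccc2nc(NC(c3cn(-c4ccccc4)nc3-c3cccc([N+](=O)[O-])c3)c3c(O)ccc4ccccc34)sc2c1` gives 7360 nM
Compound 2 `COc1ccc2nc(NC(c3cn(-c4ccccc4)nc3-c3ccc(F)cc3)c3c(O)ccc4ccccc34)sc2c1` gives 4630 nM

The two values lie within the scatter of each other, so compound 2 stands level with compound 1 in this assay and neither can be ranked ahead. Compound 3 `COc1ccc2nc(NC(c3cn(-c4ccccc4)nc3-c3ccccc3)c3c(O)ccc4ccccc34)sc2c1` has not yet been measured. It departs from compound 2 by a single change, namely hydrogen in place of fluoro on an aromatic carbon and in words hydrogen in place of fluoro on an aromatic carbon, which turns 4-fluorophenyl into phenyl. Among the measured compounds shown here, no measured pair shows this change, so the data give no direct guide to its size. The expectation therefore rests on compound 2 at 4630 nM as its reference point. The estimated 1.1-fold higher number from compound 2 to compound 3 (0.03 log units; within the scatter) is expected to stay within the scatter, with no firm direction in this assay as a result. For compound 3 the estimate is 5000 nM with an expected range of 2000 nM to 12000 nM once it is measured.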

Compound 3, half-maximal inhibitory concentration: 8290 nM
Beside the measured number, compound 3's estimate is 1.7-fold (0.22 log units) below it; measured number inside the range.
By their numbers in this assay, from the lowest: compounds 2, 1 and 3 (each within the scatter of the next).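

The first pair differing in one place gives a direct reading of this position: in this assay, hydrogen in place of fluoro on an aromatic carbon, para to a large group, gives a 1.8-fold higher number from compound 2 to compound 3 (0.25 log units; within the scatter). On this carbon, then, the exchange of 4-fluorophenyl to phenyl leaves no difference that stands clear of the scatter, so the single fluorine shows no measurable bearing on the read-out here. Nothing measured alongside these values offers an explanation for this reading.

Going by these compounds, only fluoro and hydrogen can be compared at this position, so it remains open whether an amine, a carboxylic acid or a longer chain on the same carbon would also stay within the scatter. On these data alone, it is equally open whether the same exchange would read alike with other groups elsewhere on the shared core.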